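The source may hold more compounds than are shown below. What is called first, only, known or untested is meant among the compounds shown, and "the series" means these compounds.

Compound 1, `N=C(N)c1ccc(C(=O)NCC[C@H]2C(=O)N(CC(=O)O)CCN2C(=O)CNC(=O)c2ccc(C(=N)N)cc2)cc1`, is the weakest inhibitor among the three measured compounds: in a functional assay for inhibition, with Cavia porcellus as the target (on this read-out lower numbers stand for stronger inhibition and higher numbers for weaker inhibition), compound 1 gives 190 nM, the highest of the three numbers. Compound 2, `N=C(N)Nc1ccc(C(=O)NCCC[C@H]2C(=O)N(CC(=O)O)CCN2C(=O)CNC(=O)c2ccc(NC(=N)N)cc2)cc1`, gives 51 nM in this assay, and compound 3, `N=C(N)Nc1ccc(C(=O)NCC[C@H]2C(=O)N(CC(=O)O)CCN2C(=O)CNC(=O)c2ccc(C(=N)N)cc2)cc1`, gives 37 nM. Within the data shown here, the one step between compounds that differ in a single place is a 5.1-fold lower number from compound 1 to compound 3 (0.71 log units; beyond the scatter), which exchanges one small nitrogen-rich group for another on the aromatic ring.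

Compound 4, `N=C(N)c1ccc(C(=O)NCC(=O)N2CCN(CC(=O)O)C(=O)[C@@H]2CCCNC(=O)CCCCCN)cc1`, differs from compound 1 in a different way: a group of 10 heavy atoms (7 carbon, 2 nitrogen, 1 oxygen; no ring) in place of a group of 12 heavy atoms (8 carbon, 3 nitrogen, 1 oxygen; one six-membered aromatic ring of carbon only), on a saturated chain carbon, two bonds along the chain from a saturated ring carbon. Here the whole ring-bearing arm is removed and a flexible chain ending in an amine takes its place. Among the measured compounds shown here, no measured step touches this kind of change; the step from compound 1 to compound 3 only alters a group on the ring that compound 4 no longer carries, so it gives no direct guide. With the aromatic arm gone, a weaker result is expected, and the uncertainty is large. The expected outcome for compound 4 is a 7.9-fold higher number from compound 1 to compound 4 (0.90 log units; beyond the scatter), a higher number than compound 1. Compound 4 is therefore estimated at 1500 nM in this assay, within a range from 300 nM to 8000 nM.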

Compound 4, half-maximal inhibitory concentration: 160 nM
For compound 4 the middle estimate is 9.4-fold (0.97 log units) above the measured one; measured number outside the range, below it.
By their numbers in this assay, from the lowest: compounds 3 and 2 (each within the scatter of the next); then compounds 4 and 1 (each within the scatter of the next).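

Placing the (((5-aminopentyl)carbonyl)amino)methyl group on a saturated chain carbon, two bonds along the chain from a saturated ring carbon, in place of the ring-bearing group of compound 1 gives a 1.2-fold lower number from compound 1 to compound 4 (0.07 log units; within the scatter) in this assay, so the two numbers cannot be told apart. The earlier step altered only a group on an aromatic ring, whereas this pair shows that, on this core, a number of this size does not depend on having that six-membered aromatic ring of carbon only at this position, since a group with no ring serves here as well. Nothing measured explains why two such different groups give numbers this close.

This rests on a single pair, so the compounds shown leave open whether the amine at the end of the new chain matters, as they include no version of this chain ending in a carboxylic acid or a methyl group, and no shorter or longer chain. They also leave open whether the same chain would give a comparable number alongside the other ring group found in compound 3.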